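Swapping azetidin-3-yl for oxetan-3-yl on compound 2

A few compounds are considered here, and "the series" means these few. Any claim that something is new, unique, unknown or untested is made for them only; others in the source may bear on it.

Of the compounds shown here, two have been measured so far. In an ADME assay on a cell-free system (plasma, Mus musculus) for metabolic stability (on this read-out higher numbers stand for a longer-lived compound and lower numbers for a shorter-lived compound), compound 1 `CCC(=O)N1c2ccc(-c3ccc(S(C)(=O)=O)cc3)cc2N(C(=O)c2ccco2)C[C@@H]1C` gives 0.3 h. In this assay compound 2 `CC(=O)N1c2ccc(-c3cnn(C4CNC4)c3)cc2N(C(=O)C2CC2)C[C@@H]1C` gives > 0.4 h, and this is a limit of the assay, not a number. On these data alone, compound 2 therefore stands at the limit of > 0.4 h in this assay, at which 1 of the 2 values shown sits, and its exact half-life remains unknown.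

The next compound to be measured is compound 3 `CC(=O)N1c2ccc(-c3cnn(C4COC4)c3)cc2N(C(=O)C2CC2)C[C@@H]1C`. It keeps the rest of compound 2 and carries oxetan-3-yl in place of azetidin-3-yl on an aromatic nitrogen. Cut one bond further out, the same difference reads 1-(azetidin-3-yl)-1H-pyrazol-4-yl to 1-(oxetan-3-yl)-1H-pyrazol-4-yl.

Within the data shown here, no measured pair shows what this change does in this assay. No step beyond the usual scatter is therefore expected, and neither direction is favoured. The estimated step is a step that the limit leaves unreadable from compound 2 to compound 3, which is expected to stay within that scatter. For compound 3 the expected half-life is 0.5 h, with an estimated range from 0.25 h to 1.2 h.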

Compound 3, half-life: > 0.4 h
Compound 3: only a limit was reported; the forecaster's own chance of this, stated with the estimate: 60%; the middle value does not contradict the limit.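

No step from compound 2 to compound 3 can be read in this assay, because the results for both compounds are limits of the assay and not numbers: the limit of > 0.4 h in this assay, at which 2 of the 3 values shown sit.

The compounds shown leave open what oxetan-3-yl in place of azetidin-3-yl on an aromatic nitrogen does to the half-life in this assay, in size or in direction.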